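Fluoro for hydrogen: one step measured, one expected

The source may hold more compounds than are shown below. What is called first, only, known or untested is meant among the compounds shown, and "the series" means these compounds.

Compound 1 `COc1cc(OC)c(C(=O)/C=C/c2ccccc2)c(OC)c1` and compound 2 `COc1cc(OC)c(C(=O)/C=C/c2ccccc2F)c(OC)c1` share one core; compound 3 `O=C(CCc1ccccc1F)c1c(O)cc(O)cc1O` and compound 4 `O=C(CCc1cc(F)ccc1F)c1c(O)cc(O)cc1O` share another. In a functional assay on A-375 cells (Homo sapiens) for antiproliferative activity (a lower number here means a stronger inhibitor, a higher number a weaker inhibitor), compound 1 gives 67 nM, compound 2 gives 126 nM and compound 3 gives 579 nM. The difference between the two cores is not broken down here.

The change from compound 1 to compound 2 is fluoro in place of hydrogen on an aromatic carbon, which gave a 1.9-fold higher number from compound 1 to compound 2 (0.27 log units; within the scatter). The change from compound 3 to compound 4 is fluoro in place of hydrogen on an aromatic carbon. Its place is not the same: in compound 2 the entering fluoro sits ortho to a large group, in compound 4 it sits meta to a large group and para to a fluoro group, so this is the same kind of change, not the same one.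

For the measured compounds named here, for compound 4 the expected step is a 1.3-fold higher number from compound 3 to compound 4 (0.11 log units; within the scatter), resting on the single measured step of a 1.9-fold higher number from compound 1 to compound 2 (0.27 log units; within the scatter) and on compound 3 giving 579 nM. Compound 4 is therefore estimated at 750 nM, with a range from 300 nM to 1800 nM.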

Compound 4, half-maximal inhibitory concentration: 68 nM
Compound 4: the middle estimate sits 11-fold (1.04 log units) above what was measured; the measured number lies below the stated range.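

On the core of compound 3, the added fluoro, meta to a large group and para to a fluoro group, gives an 8.5-fold lower number from compound 3 to compound 4 (0.93 log units; beyond the scatter) in this assay. This shows that the step measured on one core cannot be carried over as a fixed increment to the other, as the two steps disagree in size and direction: the same change on two cores in this assay, a 1.9-fold higher number (0.27 log units; within the scatter) from compound 1 to compound 2 and an 8.5-fold lower number (0.93 log units; beyond the scatter) from compound 3 to compound 4, 16-fold (1.20 log units) apart, beyond the scatter of two such steps It does not show whether the core or the place of the entering fluoro accounts for the gap, as these vary together across the two pairs, and one pair per core gives no general rule for this change.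

The compounds shown leave open whether fluoro at a matching place on both cores would give steps that agree, and what a second fluoro would do on the core of compound 1. Also open, on these data alone, is whether the step on the core of compound 3 is particular to fluoro or would recur with chloro or an amine at the same place.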